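This account rests on a few compounds, and the source may have more. Where it says the series, first, only, none or still open, it means among the compounds named here.

Measured in a functional assay on V79-379A cells (Cricetulus griseus) for cytotoxicity, read by MTT assay, in the presence of a further agent that is not named here; on this read-out higher numbers stand for weaker inhibition and lower numbers for stronger inhibition:
- compound 1 `COC1=CC(=O)c2c(c(COCc3ccccc3)c(C)n2C)C1=O`: 410000 nM
- compound 2 `COC1=CC(=O)c2c(c(COc3ccccc3)c(C)n2C)C1=O`: 700 nM
- compound 3 `COC1=CC(=O)c2c(c(COc3ccc(F)cc3)c(C)n2C)C1=O`: 850 nM

Compound 3 is not separated from its nearest neighbour: a 1.2-fold higher number from compound 2 to compound 3 (0.08 log units; within the scatter). Its furthest neighbour gives a 480-fold lower number from compound 1 to compound 3 (2.68 log units; beyond the scatter). Compound 4 `COC1=CC(=O)c2c(c(Cc3cc(F)ccc3O)c(C)n2C)C1=O` has the same atoms joined differently, with 5-fluoro-2-hydroxyphenyl in place of 4-fluorophenoxy on a saturated chain carbon bound to an aromatic carbon. The closest evidence is a 590-fold lower number from compound 1 to compound 2 (2.77 log units; beyond the scatter), together with a 480-fold lower number from compound 1 to compound 3 (2.68 log units; beyond the scatter); both show large movement when the group at this chain changes. Going by the values given here, no measured compound carries the new arrangement, so the size remains poorly fixed. In this assay a large move to a higher number is expected, with wide uncertainty: a 9.4-fold higher number from compound 3 to compound 4 (0.97 log units; beyond the scatter). The estimate for compound 4 is 8000 nM, within an expected range of 800 nM to 100000 nM.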

Compound 4, half-maximal inhibitory concentration: 110000 nM
For compound 4 the middle estimate is 14-fold (1.14 log units) below the measured one, and the stated range ends below it.
By their numbers in this assay, from the lowest: compounds 2 and 3 (each within the scatter of the next); then compound 4; then compound 1.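

In this assay, rejoining the same atoms as 5-fluoro-2-hydroxyphenyl on the saturated chain carbon gives a 130-fold higher number from compound 3 to compound 4 (2.11 log units; beyond the scatter), so at this position the connectivity matters, not just the composition. The same group gives a 160-fold higher number from compound 2 to compound 4 (2.20 log units; beyond the scatter) against phenoxy, but only a 3.7-fold lower number from compound 1 to compound 4 (0.57 log units; beyond the scatter) against benzyloxy, leaving compound 4 nearer to compound 1 than to the two aryl ethers. No measurement here explains the loss.

As far as these compounds go, whether a 2-methoxyphenyl group or an unfluorinated 2-hydroxyphenyl group would track compound 4 or compound 2 remains open.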